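Changing the benzyl substituent pattern in a sulfonamide diamine series

The source may report more compounds than this note shows. Statements on the series, on what has been measured and on what is new or still open speak of the compounds shown alone.

Of the compounds shown here, three sharing one core have been measured. Compound 1 `O=S(=O)(NCCCNCc1cccc2ccccc12)c1cc(C(F)(F)F)cc(C(F)(F)F)c1` gives 2700 nM in a functional assay on Capan-2 cells (Homo sapiens) for inhibition, read by MTT assay, with a stated time of 72 h; a higher number here means a weaker inhibitor of growth, a lower number a stronger inhibitor of growth. Compound 2 `O=S(=O)(NCCCNCc1ccc(Cl)cc1)c1cc(C(F)(F)F)cc(C(F)(F)F)c1` gives 2700 nM in this assay, and the step of no change at the digits printed from compound 1 to compound 2 (within the scatter) lies within the scatter. Compound 3 `O=S(=O)(NCCCNCc1cccc(Cl)c1)c1cc(C(F)(F)F)cc(C(F)(F)F)c1` gives 8000 nM, the highest of the three numbers, standing a 3.0-fold higher number from compound 1 to compound 3 (0.47 log units; beyond the scatter) and a 3.0-fold higher number from compound 2 to compound 3 (0.47 log units; beyond the scatter) apart from the other two.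

The next compound, compound 4 `O=S(=O)(NCCCNCc1ccc(C(F)(F)F)cc1)c1cc(C(F)(F)F)cc(C(F)(F)F)c1`, differs from compound 3 in one place: 4-(trifluoromethyl)phenyl in place of 3-chlorophenyl on a saturated chain carbon bound to an amine nitrogen. The step that bears on this most directly is a 3.0-fold higher number from compound 2 to compound 3 (0.47 log units; beyond the scatter), which shows that shifting the substituent from the 4-position to the 3-position gave a modestly higher number. Going by the values given here, compound 4 returns the substituent to the 4-position, so a modest fall toward the numbers of compound 1 and compound 2 is expected, though no measured step covers a trifluoromethyl group in this place. The expected step is a 2.7-fold lower number from compound 3 to compound 4 (0.43 log units; beyond the scatter), and the estimated value for compound 4 is 3000 nM, in a range from 1200 nM to 8000 nM.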

Compound 4, concentration for 50% growth inhibition: 2000 nM
For compound 4 the middle estimate is 1.5-fold (0.18 log units) above the measured one, within the range that was stated.
By their numbers in this assay, from the lowest: compounds 4, 1 and 2 (each within the scatter of the next); then compound 3.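

Putting 4-(trifluoromethyl)phenyl in place of 3-chlorophenyl on the saturated chain carbon bound to the amine nitrogen gives a 4.0-fold lower number from compound 3 to compound 4 (0.60 log units; beyond the scatter) in this assay, which leaves compound 3 as the only one of the four set apart from the rest. Trifluoromethyl in place of chloro on the aromatic carbon gives a 1.4-fold lower number from compound 2 to compound 4 (0.13 log units; within the scatter), and 4-(trifluoromethyl)phenyl in place of naphthalen-1-yl gives a 1.4-fold lower number from compound 1 to compound 4 (0.13 log units; within the scatter), so these three different groups cannot be told apart at this position. No measurement offered here explains these numbers.

A 3-(trifluoromethyl)phenyl group would help show whether the higher number of compound 3 goes with that ring position or with the chloro group itself. Going by these compounds, a methoxy group or a nitrile on the ring, or a longer chain in the core, remains open as well.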